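Methyl on the amine nitrogen: compound 2 to compound 4

The compounds below may be only part of what the source reports. "The series", "measured", "known", "first", "only" and "open" are said of these compounds alone.

The series shares the core of compound 2 `CNCCCNc1c(C(=O)NCc2ccc(F)cc2)nc(Br)c2cccnc12`, with compound 1 `CS(=O)(=O)Oc1c(C(=O)NCc2ccc(F)cc2)nc(Br)c2cccnc12` and compound 3 `COc1ccc(CNC(=O)c2nc(Br)c3cccnc3c2N[C@H]2CC[C@H](N)CC2)cc1` alongside it. In a functional assay on MCF7 cells (Homo sapiens) for cytotoxicity, read by MTT assay, with a stated time of 72 h (a lower number here means a stronger inhibitor, a higher number a weaker inhibitor), compound 1 gives "not determined" (no result reported). In this assay compound 3 gives "not determined" (no result reported). For compound 2 the result is only a limit of the assay, > 10000 nM, not a number. For the measured compounds named here, compound 2 is thus the only entry with a reading of any kind, and it sits at the limit of > 10000 nM in this assay, at which 1 of the 3 values shown sits. Going by the values given here, no step between two measured compounds exists in this set, so no measured size of change is known here.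

Compound 4 `CN(C)CCCNc1c(C(=O)NCc2ccc(F)cc2)nc(Br)c2cccnc12` is the next compound to be tested. Its difference from compound 2 is methyl in place of hydrogen on an amine nitrogen. With only a limit on compound 2, the expected change a step that the limit leaves unreadable from compound 2 to compound 4 is small and in no direction beyond the usual scatter. Compound 4 is therefore estimated at 15000 nM, within 6000 nM to 40000 nM, and the likeliest outcome is again a limit rather than a number.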

Compound 4, half-maximal inhibitory concentration: 7000 nM
Compound 4: middle estimate off by 2.1-fold (0.33 log units), on the high side; the range from low to high includes it.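

For the compounds shown here, compound 4 gives 7000 nM in this assay, the first reading that is a number rather than a limit, so a dimethylamino end on this chain can be placed on the scale of the assay. For compound 2 the reading is only a limit of the assay: the limit of > 10000 nM in this assay, at which 1 of the 4 values shown sits. The change from methylamino to dimethylamino therefore reads as an at least 1.4-fold lower number from compound 2 to compound 4 (0.15 log units; that floor lies within the scatter), which fixes only a floor for the step and leaves its true size unknown.

The compounds shown leave open how a larger group on the same nitrogen, such as ethyl, or a cyclic amine such as piperidine, would read against compound 4. Also open, as far as these compounds go, is what a longer chain between the core and the dimethylamino group would give.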